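This account rests on a few compounds, and the source may have more. Where it says the series, first, only, none or still open, it means among the compounds named here.

Compound 1 `CNc1nc(Nc2ccc(C)c(N)c2)ncc1C(=O)Nc1cc(NC(=O)c2cccc(C(F)(F)F)c2)ccc1C` yields only a limit in an ADME assay on BaF3 cells (Mus musculus) for antiproliferative activity, read by CellTiter-Glo and CCK-8 assay, with a stated time of 72 h; a lower number here means a stronger inhibitor of growth, a higher number a weaker inhibitor of growth: compound 1 gives > 10000 nM, a limit of the assay rather than a number. Compound 2 `Cc1ccc(Nc2ncc(C(=O)Nc3cc(NC(=O)c4cccc(C(F)(F)F)c4)ccc3C)c(N(C)C)n2)cc1N` likewise gives > 10000 nM, again a limit. The step that the two limits leave unreadable from compound 1 to compound 2 is unreadable, since both values sit at the limit of > 10000 nM in this assay, at which 2 of the 2 values shown sit. Compound 3 `CNc1nc(Nc2ccc(C)c(N)c2)ncc1C(=O)Nc1cc(NC(=O)c2ccccc2OC)ccc1C` differs from compound 1 by 2-methoxyphenyl in place of 3-(trifluoromethyl)phenyl on a carbonyl carbon. For the measured compounds named here, no measured step bears on this change, and compound 1 stands at a limit only. Compound 3 is expected to stay near that limit, with an estimate of 10000 nM spanning 3000 nM to 30000 nM. The expected step of a number no higher from compound 1 to compound 3 (the limit leaves the size open) is thus none readable beyond the scatter.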

Compound 3, concentration for 50% growth inhibition: > 10000 nM
Compound 3 gave a limit, no number; the forecaster's own chance of this, stated with the estimate: 75%; the middle value sits exactly at the limit.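

No step can be read between compound 1 and compound 3, as both stand at a limit and not a number: the limit of > 10000 nM in this assay, at which 3 of the 3 values shown sit. In this assay the compounds shown leave open what number lies behind that limit for any of them.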